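The compounds below may be only part of what the source reports. "The series", "measured", "known", "first", "only" and "open" are said of these compounds alone.

Working notes on the series. Compound 3 `C=CCN(C)C(=O)c1ccc(C(CC)(CC)c2ccc(OCC(=O)C(C)(C)C)c(C)c2)n1CC` gives 21600 nM in an assay on HL-60 cells for agonist activity at vitamin D3 receptor (Homo sapiens), read by microscopy, with a stated time of 96 h (a lower number here means that less compound is needed, a higher number that more compound is needed for the effect), and sits at the highest number of the three measured. Compound 1 `C#CCNC(=O)c1ccc(C(CC)(CC)c2ccc(OCC(=O)C(C)(C)C)c(C)c2)n1CC` gives 2200 nM and compound 2 `CCn1c(C(=O)NCCN)ccc1C(CC)(CC)c1ccc(OCC(=O)C(C)(C)C)c(C)c1` gives 120 nM; both steps onto compound 3 are beyond the scatter: a 9.8-fold higher number from compound 1 to compound 3 (0.99 log units; beyond the scatter) and a 180-fold higher number from compound 2 to compound 3 (2.26 log units; beyond the scatter). Compound 4 `C#CCCOC(=O)c1ccc(C(CC)(CC)c2ccc(OCC(=O)C(C)(C)C)c(C)c2)n1CC` is not yet measured. The change from compound 3 is (but-3-yn-1-yl)oxy in place of allyl(methyl)amino on a carbonyl carbon. Within the data shown here, no measured step replaces the amide nitrogen with an oxygen, so the bearing of the known steps is indirect. What they show is that changes on this carbonyl carbon move the number substantially: a 9.8-fold higher number from compound 1 to compound 3 (0.99 log units; beyond the scatter) and a 180-fold higher number from compound 2 to compound 3 (2.26 log units; beyond the scatter). Compound 4, like compound 3, carries no hydrogen-bond donor on the group at the carbonyl carbon, and compound 3 is the weakest measured; a step of moderate size in either direction is plausible, so the expected step of a 2.2-fold lower number from compound 3 to compound 4 (0.33 log units; beyond the scatter) is centred near a modest decrease, with wide bounds. The estimate for compound 4 in this assay is 10000 nM, between 2000 nM and 50000 nM.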

Compound 4, half-maximal effective concentration: 28800 nM
For compound 4 the middle estimate is 2.9-fold (0.46 log units) below the measured one; low and high end bracket the measured number.
By their numbers in this assay, from the lowest: compound 2; then compound 1; then compounds 3 and 4 (each within the scatter of the next).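

Compound 4 adds a new kind of link at this carbonyl carbon: (but-3-yn-1-yl)oxy in place of allyl(methyl)amino leaves the number in this assay within the scatter, a 1.3-fold higher number from compound 3 to compound 4 (0.12 log units; within the scatter). Replacing either nitrogen-linked group that has a hydrogen on its amide nitrogen with (but-3-yn-1-yl)oxy has a much larger effect, a 13-fold higher number from compound 1 to compound 4 (1.12 log units; beyond the scatter) and a 240-fold higher number from compound 2 to compound 4 (2.38 log units; beyond the scatter), so compounds 3 and 4 together stand at the high end of the series. No available evidence explains these steps.

From the compounds shown here alone, it remains open whether the low number of compound 2 depends on its terminal amine or on the amide hydrogen, which a (2-hydroxyethyl)amino group could help separate. Going by these compounds, a carboxylic acid on this carbonyl carbon, or a longer chain ending in an amine, also remains open.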